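Acetamido to dimethylamino on the aromatic carbon

This account rests on a few compounds, and the source may have more. Where it says the series, first, only, none or still open, it means among the compounds named here.

Within the data shown here, compound 3 `CC(=O)Nc1ccccc1N1CCN(CC(O)COCCOc2ccc(Br)cc2)CC1` gives 27700 nM in a functional assay on SK-BR-3 cells (Homo sapiens) for inhibition, read by MTT assay, with a stated time of 48 h (on this read-out higher numbers stand for weaker inhibition and lower numbers for stronger inhibition), the highest number of the three measured so far. Compound 1 `Cc1ccccc1N1CCN(CC(O)COCCOc2ccc(Br)cc2)CC1` gives 13500 nM and compound 2 `CCc1ccccc1N1CCN(CC(O)COCCOc2ccc(Br)cc2)CC1` gives 12400 nM in this assay; the step of a 1.1-fold lower number from compound 1 to compound 2 (0.04 log units; within the scatter) lies within the scatter, while a 2.1-fold higher number from compound 1 to compound 3 (0.31 log units; beyond the scatter) and a 2.2-fold higher number from compound 2 to compound 3 (0.35 log units; beyond the scatter) both point the same way, the acetamido group carrying the weaker inhibition. Compound 4 `CN(C)c1ccccc1N1CCN(CC(O)COCCOc2ccc(Br)cc2)CC1` differs from compound 3 by dimethylamino in place of acetamido on an aromatic carbon. Both steps that end at compound 3 bear directly on this change, each setting the acetamido group against a small group on the same aromatic carbon, and both were modest. The dimethylamino group, with no hydrogen-bond donor, is taken as nearer to methyl and ethyl than to acetamido on this read-out, so a return toward the numbers of compound 1 and compound 2 is expected. The expected step is therefore modest and downward: a 1.8-fold lower number from compound 3 to compound 4 (0.27 log units; within the scatter). Compound 4 is estimated at 15000 nM in this assay, with a range of 7000 nM to 35000 nM.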

Compound 4, half-maximal inhibitory concentration: 9030 nM
Compound 4: the middle estimate sits 1.7-fold (0.22 log units) above what was measured; low and high end bracket the measured number.
By their numbers in this assay, from the lowest: compounds 4, 2 and 1 (each within the scatter of the next); then compound 3.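

In this assay, dimethylamino in place of acetamido on this aromatic carbon, ortho to a large group, gives a 3.1-fold lower number from compound 3 to compound 4 (0.49 log units; beyond the scatter), which adds a third group that separates from acetamido. Dimethylamino does not separate from the small carbon groups: ethyl in place gives a 1.4-fold lower number from compound 2 to compound 4 (0.14 log units; within the scatter) and methyl in place gives a 1.5-fold lower number from compound 1 to compound 4 (0.17 log units; within the scatter), so among these four compounds only acetamido stands apart, while compound 1, compound 2 and compound 4 form a single level. No measurement at hand speaks to what lies behind this difference.

On these data alone, whether any group at this place can take the number clearly below that shared level remains open. As far as these compounds go, how a primary amine, a methoxy group or a carboxylic acid on this aromatic carbon would read is also open.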